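This account rests on a few compounds, and the source may have more. Where it says the series, first, only, none or still open, it means among the compounds named here.

In a functional assay on HepG2 cells (Homo sapiens) for inhibition, read by MTT assay, with a stated time of 72 h (a higher number here means a weaker inhibitor, a lower number a stronger inhibitor), compound 1 (`Brc1ccc(-c2nnc(SCCCN3CCN(c4nc5ccccc5o4)CC3)o2)cc1`) gives 67500 nM, and compound 2 (`Cc1ccc(-c2nnc(SCCCN3CCN(c4nc5ccccc5s4)CC3)o2)cc1`) gives 96700 nM. These two values lie within the usual scatter of each other, so compound 2 stands level with compound 1 and the numbers do not rank them.

Compound 3 (`c1ccc(-c2nnc(SCCCN3CCN(c4nc5ccccc5s4)CC3)o2)cc1`) has not yet been measured in this assay. It differs from compound 2 at one place, with hydrogen in place of methyl on an aromatic carbon, para to a large group, so that 4-methylphenyl becomes phenyl: hydrogen in place of methyl on an aromatic carbon. Going by the values given here, no measured pair here differs in one place only, so the data give no direct guide to the size of this step. With so small a change, no shift beyond the scatter is expected, and neither direction is favoured. The expectation rests on compound 2 at 96700 nM. The expected step of a 1.1-fold lower number from compound 2 to compound 3 (0.06 log units; within the scatter) stays within the scatter. For compound 3 the estimated value is 85000 nM, with an expected range from 35000 nM to 200000 nM.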

Compound 3, half-maximal inhibitory concentration: 217000 nM
The estimate for compound 3 lay 2.6-fold (0.41 log units) below the measured number; the whole stated range lies below it.
By their numbers in this assay, from the lowest: compounds 1 and 2 (each within the scatter of the next); then compound 3.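

The step gives the series its first comparison of compounds that differ in one place: in this assay, the change from 4-methylphenyl to phenyl gives a 2.2-fold higher number from compound 2 to compound 3 (0.35 log units; beyond the scatter). This shows that the aromatic carbon para to a large group is not indifferent to this small change, since hydrogen in place of methyl moves the number towards weaker inhibition, by a modest amount but beyond the scatter. Nothing shown gives a measured reason for this step, so it stands as an observation from a single pair.

The compounds shown leave open whether the methyl itself matters or whether other groups at this place, such as methoxy, an amine or a carboxylic acid, would give a number as low as that of compound 2 or lower. They also leave open whether the same change would have a similar effect on the core of compound 1, which differs from compound 2 in more than one place and so gives no direct reading of this step.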